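The compounds below may be only part of what the source reports. "The series", "measured", "known", "first", "only" and "open" are said of these compounds alone.

Measured so far:
compound 1, `CCCCOc1ccc(NC(=O)n2nc(N)c3ccccc32)cc1`: 18800 nM
compound 2, `Nc1nn(C(=O)Nc2c(F)cccc2F)c2ccccc12`: 65700 nM

In a functional assay on OVCAR-3 cells (Homo sapiens) for inhibition, read by sulforhodamine B assay, with a stated time of 48 h (a lower number here means a stronger inhibitor of growth, a higher number a weaker inhibitor of growth), compound 1 gives 18800 nM, the lowest of the two numbers. Compound 2 gives 65700 nM, a gap beyond the usual scatter. Compound 3, `Nc1nn(C(=O)Nc2ccc(Cc3ccccc3)cc2)c2ccccc12`, has not been measured. It differs from compound 1 in one place: benzyl in place of butoxy on an aromatic carbon. Among the compounds with values here, no step between measured compounds shows this change, so the expectation rests on the change alone. The step from compound 1 to compound 3 in this assay is expected to be small, at most a modest move to a lower number and possibly none beyond the scatter. The expected step is a 1.6-fold lower number from compound 1 to compound 3 (0.19 log units; within the scatter). Compound 3 is expected at 12000 nM, within 4000 nM to 40000 nM.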

Compound 3, concentration for 50% growth inhibition: 6230 nM
For compound 3 the middle estimate is 1.9-fold (0.28 log units) above the measured one; the range from low to high includes it.
By their numbers in this assay, from the lowest: compound 3; then compound 1; then compound 2.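

In this assay benzyl in place of butoxy gives a 3.0-fold lower number from compound 1 to compound 3 (0.48 log units; beyond the scatter) on an aromatic carbon para to a large group. This position therefore accepts a six-membered aromatic ring in place of an open chain, and the number falls rather than rises. Nothing on hand accounts for the step.

As far as these compounds go, whether the step follows from the ring, its single-carbon link or the loss of the oxygen stays open. A phenoxy group, a longer alkoxy chain or an amine at this position would help separate these.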